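A few compounds are considered here, and "the series" means these few. Any claim that something is new, unique, unknown or untested is made for them only; others in the source may bear on it.

Compound 2 `Clc1ccc(Sc2ccc(NC3=NCCN3)cc2)cc1` gives 79.4 nM in an assay (Rattus norvegicus) for binding affinity to prostacyclin receptor (Homo sapiens), read by radioligand binding (on this read-out lower numbers stand for stronger inhibition and higher numbers for weaker inhibition), the lowest of the three numbers recorded so far. Compound 1 `CC/N=C(\N)Nc1ccc(Sc2ccc(Cl)cc2)cc1` gives 631 nM in this assay, and compound 3 `COc1ccc(OC)c(Sc2ccc(NC3=NCCN3)cc2)c1` gives 794 nM. The only step shown, a 7.9-fold lower number from compound 1 to compound 2 (0.90 log units; beyond the scatter), concerns the group on the nitrogen rather than the chloro, so it does not bear directly on the change to compound 4 `CCOC(=O)c1ccc(Sc2ccc(NC3=NCCN3)cc2)cc1`, which is ethoxycarbonyl in place of chloro on an aromatic carbon. Going by the values given here, no measured step tells what ethoxycarbonyl does at this place; compound 3 shows only that a different replacement of the chloro leaves a higher number than compound 2. A modest move toward a higher number is therefore expected, a 3.1-fold higher number from compound 2 to compound 4 (0.50 log units; beyond the scatter). For compound 4 the estimate is 250 nM, within 60 nM to 1000 nM.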

Compound 4, inhibition constant: 50.1 nM
Estimate against measurement, compound 4: 5.0-fold (0.70 log units) above; the measured number lies below the stated range.
By their numbers in this assay, from the lowest: compounds 4 and 2 (each within the scatter of the next); then compounds 1 and 3 (each within the scatter of the next).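

Ethoxycarbonyl in place of chloro, para to a large group, gives a 1.6-fold lower number from compound 2 to compound 4 (0.20 log units; within the scatter) in this assay, so the two groups cannot be told apart at this place. Going by these compounds alone, a group of five heavy atoms with two hydrogen-bond acceptors thus leaves the number within the scatter of that for a single chlorine, which the earlier compounds did not show. No measurement offered here accounts for this result.

Going by these compounds, whether a carboxylic acid, an amine or a longer ester chain at this place would also hold the number there stays open.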